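Thiadiazole to tetrazole swap on the thioether arm

The source may report more compounds than this note shows. Statements on the series, on what has been measured and on what is new or still open speak of the compounds shown alone.

Measured so far in a functional assay on C6 cells (Rattus norvegicus) for cytotoxicity, read by MTT assay, with a stated time of 24 h, tested at 100 ug/mL; a higher number here means a weaker effect of the compound at the concentration tested, a lower number a stronger effect:
compound 1 `Cc1nnc(SCC(=O)N/N=c2/scc(-c3ccccc3)n2-c2ccccc2)s1`: 61.8%
compound 2 `Cc1nnc(SCC(=O)N/N=c2/scc(-c3ccc(Cl)cc3)n2-c2ccccc2)s1`: 34.1%

Compound 1 gives the highest of the two numbers in this assay; its nearest neighbour is compound 2, and the step of a number 27.7 percentage points lower from compound 1 to compound 2 (beyond the scatter) came with a chloro in place of hydrogen on an aromatic carbon. Compound 3 `Cn1nnnc1SCC(=O)N/N=c1/scc(-c2ccccc2)n1-c1ccccc1` is still to be measured. It differs from compound 1 in one place: 1-methyl-1H-tetrazol-5-yl in place of 5-methyl-1,3,4-thiadiazol-2-yl on a sulfur. Among the measured compounds shown here, the only measured step concerns a substituent on an aromatic carbon, not the group on the sulfur, so no measured step bears directly on the change from compound 1 to compound 3. With nothing in the series that speaks for a shift, the step of a number 3.8 percentage points lower from compound 1 to compound 3 (within the scatter) is expected to stay within the scatter. For compound 3 the estimate in this assay is 58%, with a range from 35% to 80%.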

Compound 3, a percentage reported as activity, at one concentration (the size of the read-out at that concentration, not a potency): 38.8%
The estimate for compound 3 lay 19.2 percentage points above the measured number, and the stated range covers the measured number.
By their numbers in this assay, from the lowest: compounds 2 and 3 (each within the scatter of the next); then compound 1.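

The group on the sulfur is not a silent position in this assay: 1-methyl-1H-tetrazol-5-yl in place of 5-methyl-1,3,4-thiadiazol-2-yl gives a number 23 percentage points lower from compound 1 to compound 3 (beyond the scatter), so the read-out responds to this arm as well as to the aromatic chloro substitution. The swap keeps the count of 6 heavy atoms, while the ring sulfur gives way to nitrogen and the hydrogen-bond acceptor count rises, and this single pair cannot separate these differences. No measurement at hand accounts for the step.

On these data alone, whether the tetrazole arm and the chloro substituent together move the read-out further remains open. Also open, as far as these compounds go, is how a plain methyl or a phenyl on the sulfur would compare with either five-membered aromatic ring.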